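The compounds below may be only part of what the source reports. "The series", "measured", "known", "first", "only" and "open" are said of these compounds alone.

Measured in a functional assay on HCT-116 cells (Homo sapiens) for antiproliferative activity, read by MTT assay, with a stated time of 72 h; on this read-out higher numbers stand for weaker inhibition and lower numbers for stronger inhibition:
- compound 1 `COc1cccc(N2C(=O)COc3ccc(-c4cnc5ccccc5c4)cc32)c1`: 8240 nM
- compound 2 `O=C1COc2ccc(-c3ccc(O)cc3)cc2N1`: > 40000 nM

Among the compounds with values here, compound 1 holds the only actual number in this small set. Compound 2 reads > 40000 nM, which is a limit of the assay and not a number. The next compound to be tested in this assay is compound 3 `O=C1COc2ccc(-c3cnc4ccccc4c3)cc2N1c1ccc(Cl)cc1`, which keeps the core of compound 1 and carries 4-chlorophenyl in place of 3-methoxyphenyl on an amide-type nitrogen in a ring. Within the data shown here, no measured pair differs in one place only, so the data offer no direct guide to this exchange. The estimated 1.2-fold lower number from compound 1 to compound 3 (0.07 log units; within the scatter) is expected to stay within the usual scatter, with neither direction favoured. For compound 3 the expected value is 7000 nM, with an estimated range of 2500 nM to 20000 nM.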

Compound 3, half-maximal inhibitory concentration: 36100 nM
For compound 3 the middle estimate is 5.2-fold (0.71 log units) below the measured one, and the stated range ends below it.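

On the amide-type nitrogen in the ring, the aryl group is not a neutral place on the core of compound 1: in this assay, the exchange gives a 4.4-fold higher number from compound 1 to compound 3 (0.64 log units; beyond the scatter). On this single pair, 4-chlorophenyl serves worse than 3-methoxyphenyl at this position, although the exchange alters both the substituent and the place it holds on the phenyl ring, and the pair does not separate the two. Compound 2 gives no number to set against this, only a limit of the assay: the limit of > 40000 nM in this assay, at which 1 of the 3 values shown sits.

The compounds shown leave open how 3-chlorophenyl or 4-methoxyphenyl would read on this nitrogen, which would tell the substituent from its place. They also leave open whether an unsubstituted phenyl or a 3-aminophenyl there would give a lower number than compound 1.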